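Butyl in place of isopropyl on the carbonyl oxygen

A few compounds are considered here, and "the series" means these few. Any claim that something is new, unique, unknown or untested is made for them only; others in the source may bear on it.

Compound 1 `O=C(O)c1cc(N2C(=O)C3=C(CCCC3)C2=O)c(F)cc1Cl` reads 3160 nM in a functional assay on the whole organism with Scenedesmus acutus as the target, with a stated time of 20 h (a lower number here means a stronger inhibitor, a higher number a weaker inhibitor), compound 2 `COC(=O)c1cc(N2C(=O)C3=C(CCCC3)C2=O)c(F)cc1Cl` reads 170 nM there and compound 3 `CC(C)OC(=O)c1cc(N2C(=O)C3=C(CCCC3)C2=O)c(F)cc1Cl` reads 89.1 nM there. Compound 3 thus stands within the scatter of compound 2, and both lie far under compound 1. Replacing hydrogen gave large steps: a 19-fold lower number from compound 1 to compound 2 (1.27 log units; beyond the scatter) and a 35-fold lower number from compound 1 to compound 3 (1.55 log units; beyond the scatter) in turn. Compound 4 `CCCCOC(=O)c1cc(N2C(=O)C3=C(CCCC3)C2=O)c(F)cc1Cl` has butyl in place of isopropyl on an oxygen next to a carbonyl group. Within the data shown here, the closest precedent, exchanging one chain for another at that oxygen, gave only a 1.9-fold lower number from compound 2 to compound 3 (0.28 log units; within the scatter) as its step. No step beyond the scatter is therefore expected, and the estimate amounts to a 1.1-fold higher number from compound 3 to compound 4 (0.05 log units; within the scatter) in this assay as its expected size. Compound 4 is estimated at 100 nM (expected range 40 nM to 250 nM).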

Compound 4, half-maximal inhibitory concentration: 141 nM
Beside the measured number, compound 4's estimate is 1.4-fold (0.15 log units) below it, and the stated range covers the measured number.
By their numbers in this assay, from the lowest: compounds 3, 4 and 2 (each within the scatter of the next); then compound 1.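

Butyl on the oxygen next to a carbonyl group adds a third chain that cannot be separated from the others in this assay: compound 4 sits within the scatter of isopropyl (a 1.6-fold higher number from compound 3 to compound 4 (0.20 log units; within the scatter)) and of methyl (a 1.2-fold lower number from compound 2 to compound 4 (0.08 log units; within the scatter)). The large step away from the free acid also holds for butyl (a 22-fold lower number from compound 1 to compound 4 (1.35 log units; beyond the scatter)), so across these three chains the step depends on having a chain there, not on which chain it is. Nothing available explains this flat response.

Going by these compounds, a longer chain such as octyl, or a chain carrying an amine, remains open at this oxygen. Whether either would stay within the same narrow band is also unknown.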